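Amide nitrogen swap from thiazolyl to trifluoromethylphenyl

The source may hold more compounds than are shown below. What is called first, only, known or untested is meant among the compounds shown, and "the series" means these compounds.

Measured in a functional assay on DU-145 cells (Homo sapiens) for antiproliferative activity, read by sulforhodamine B assay, with a stated time of 3 days; a higher number here means a weaker inhibitor of growth, a lower number a stronger inhibitor of growth:
- compound 1 `O=C(Nc1ccccn1)c1cccc(Nc2ncc(F)c(Nc3ccc(F)cc3)n2)c1`: 15100 nM
- compound 2 `O=C(Nc1nccs1)c1cccc(Nc2ncc(F)c(Nc3ccc(F)cc3)n2)c1`: > 10000 nM (a limit)

Compound 2 stands only at a limit, given as > 10000 nM in the list and not a number. Compound 3 `O=C(Nc1ccc(C(F)(F)F)cc1)c1cccc(Nc2ncc(F)c(Nc3ccc(F)cc3)n2)c1` keeps the shared core and differs by 4-(trifluoromethyl)phenyl in place of 1,3-thiazol-2-yl on an amide-type nitrogen on the same nitrogen. For the measured compounds named here, the one measured step, a step that the limit leaves unreadable from compound 1 to compound 2, also changes the group on an amide-type nitrogen but offers no size to carry over. Resting on compound 1 at 15100 nM as the only number, no step beyond the scatter is expected in this assay here. The estimated step that the limit leaves unreadable from compound 2 to compound 3 has no firm direction. Compound 3 is estimated at 12000 nM (expected range 3000 nM to 40000 nM).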

Compound 3, concentration for 50% growth inhibition: > 10000 nM
Compound 3: a limit, no number (the forecaster's own chance of this, stated with the estimate: 45%); the middle value does not contradict the limit.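

For the compounds shown here, no step from compound 1 or compound 2 to compound 3 can be read, since compound 3 gives a limit and not a number: the limit of > 10000 nM in this assay, at which 2 of the 3 values shown sit. On these data alone, how large an effect either swap to 4-(trifluoromethyl)phenyl on the amide-type nitrogen has on growth inhibition stays open.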